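Working notes: acid variants on a shared amide scaffold

A few compounds are considered here, and "the series" means these few. Any claim that something is new, unique, unknown or untested is made for them only; others in the source may bear on it.

Measured so far in an assay for inhibition of 3-oxo-5-alpha-steroid 4-dehydrogenase 1 (Homo sapiens), tested at 10 uM; on this read-out higher numbers stand for more inhibition at the one concentration tested (going by the name of the read-out) and lower numbers for less inhibition:
compound 1 `O=C(O)c1ccc(C=C2CCN(C(=O)C(C3CCCCC3)C3CCCCC3)CC2)cc1` gives 46%
compound 2 `O=C(O)c1ccc(C=C2CCN(C(=O)C(c3ccccc3)c3ccccc3)CC2)c(F)c1` gives 2%
compound 3 `O=C(O)Cc1ccc(C=C2CCN(C(=O)C(C3CCCCC3)C3CCCCC3)CC2)cc1` gives 6%

Compound 3 stands second highest of the three numbers; compound 2 sits within the scatter of it, while compound 1 lies beyond the scatter above it. Within the data shown here, the one single-place step available, a number 40 percentage points lower from compound 1 to compound 3 (beyond the scatter), is the step that bears here. Compound 4 `O=C(O)c1ccc(C=C2CCN(C(=O)C(C3CCCCC3)C3CCCCC3)CC2)c(F)c1` differs from compound 3 by 4-carboxy-2-fluorophenyl in place of 4-(carboxymethyl)phenyl on a double-bonded chain carbon bound to a double-bonded ring carbon. Among the measured compounds shown here, this returns carboxy in place of carboxymethyl, which should reclaim most of that step, but also adds a fluorine for which no isolated step exists; compound 2, the only fluorinated compound, differs from compound 1 in two places, so it offers no clean guide. A rise of a number 24 percentage points higher from compound 3 to compound 4 (beyond the scatter) is expected in this assay, with wide uncertainty. Compound 4 is estimated at 30% (range 5% to 55%).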

Compound 4, a percentage reported as inhibition, at one concentration (the size of the read-out at that concentration, not a potency): 12%
Estimate against measurement, compound 4: 18 percentage points above, and the stated range covers the measured number.
By their numbers in this assay, from the lowest: compounds 2, 3 and 4 (each within the scatter of the next); then compound 1.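

Fluoro in place of hydrogen on an aromatic carbon now has an isolated reading in this assay, a number 34 percentage points lower from compound 1 to compound 4 (beyond the scatter), and the step is large. With a number 6 percentage points higher from compound 3 to compound 4 (within the scatter), 4-carboxy-2-fluorophenyl and 4-(carboxymethyl)phenyl cannot be told apart at this place, so the carboxy group alone does not keep the level of compound 1 at 46%. Nothing available bears on what lies behind either step.

Still open, going by these compounds, is whether a chloro group in place of the fluoro would carry the same loss, and whether a tetrazole could stand in for the carboxy group on the core of compound 1.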